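Stilbene series: sulfanyl for propoxy on the Z isomer

A few compounds are considered here, and "the series" means these few. Any claim that something is new, unique, unknown or untested is made for them only; others in the source may bear on it.

Working notes on three measured compounds and one open one.

Compound 1 `COc1cc(/C=C/c2ccc(SC)cc2)cc(OC)c1OC` gives, in a functional assay on MLM cells (Homo sapiens) for cytotoxicity, using microsomes (on this read-out lower numbers stand for an effect already at smaller amounts and higher numbers for an effect only at larger amounts of compound), a value of 7.3 uM. Compound 2 `CCCOc1ccc(/C=C\c2cc(OC)c(OC)c(OC)c2)cc1` gives 6.5 uM in this assay. Compound 3 `CCCOc1ccc(/C=C/c2cc(OC)c(OC)c(OC)c2)cc1` reaches only a limit of this assay, > 25 uM. Compound 4 `COc1cc(/C=C\c2ccc(SC)cc2)cc(OC)c1OC` is not yet measured in this assay.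

Compound 2 and compound 3 share one core and differ only as described in the two compounds have the same atoms and bonds and differ only in configuration as drawn: 1 of 1 stereo elements differ; a double bond is drawn E in compound 3 and Z in compound 2. The step of an at least 3.8-fold higher number from compound 2 to compound 3 (0.58 log units; beyond the scatter) rests on (the fact that compounds 2 and 3 differ only in the configuration as drawn), and its size is open-ended because of the limit of > 25 uM in this assay, at which 1 of the 3 values shown sits.

The change under study is methylsulfanyl in place of propoxy on an aromatic carbon: the step of an at least 3.4-fold lower number from compound 3 to compound 1 (0.53 log units; beyond the scatter) is a lower bound on the true step because of the limit of > 25 uM in this assay, at which 1 of the 3 values shown sits. The same change, at the same place as described, is made from compound 2 to compound 4: methylsulfanyl in place of propoxy on an aromatic carbon. Among the compounds shown, it occurs twice, once with a measured outcome.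

For compound 4 the expectation is a step of a 1.6-fold lower number from compound 2 to compound 4 (0.21 log units; within the scatter) in this assay, that is, a number at or somewhat below that of compound 2, whose 6.5 uM is the starting point; the direction is taken from compound 3 to compound 1 via an at least 3.4-fold lower number from compound 3 to compound 1 (0.53 log units; beyond the scatter), though with a single measured instance the size is uncertain. The estimate for compound 4 in this assay is 4 uM, expected to fall between 1.5 uM and 12 uM.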

Compound 4, concentration for half-maximal effect: 3.3 uM
Beside the measured number, compound 4's estimate is 1.2-fold (0.08 log units) above it; the measured number falls inside the stated range.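

In this assay the change keeps its direction on the core of compound 2, with a 2.0-fold lower number from compound 2 to compound 4 (0.29 log units; within the scatter), but a step of this size establishes little by itself, and the outcomes on the two cores cannot be told apart: the same change on two cores in this assay, an at least 3.4-fold lower number (0.53 log units; beyond the scatter) from compound 3 to compound 1 and a 2.0-fold lower number (0.29 log units; within the scatter) from compound 2 to compound 4; the limit leaves it open whether they differ. Compound 3 gives only a limit, > 25 uM, so the size of the change on its core stays unknown, and no transfer of a size from one core to the other is shown. With methylsulfanyl in place, the configuration of the double bond gives a 2.2-fold lower number from compound 1 to compound 4 (0.34 log units; beyond the scatter), so the Z form again carries the lower number, as in the pair of compound 2 and compound 3.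

The compounds shown leave open how far the result depends on the group itself, since an amine, a carboxylic acid or a chain longer than propoxy does not appear at this place on either core. Also open, going by these compounds, is whether the change behaves alike on both cores once a full number replaces the limit, and whether the pattern holds in any read-out other than this assay.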